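A few compounds are considered here, and "the series" means these few. Any claim that something is new, unique, unknown or untested is made for them only; others in the source may bear on it.

Measured in a functional assay on SMMC-7721 cells (Homo sapiens) for antiproliferative activity, read by MTT assay, with a stated time of 48 h; on this read-out higher numbers stand for weaker inhibition and lower numbers for stronger inhibition:

Compound 1 `CC(C)=CCC[C@]1(C)/C=C/[C@@H](OC(=O)C=C(C)C)[C@](C)(O)/C=C/C(=O)/C(CN(C)C)=C\C1` — 820 nM
Compound 2 `CC(C)=CCC[C@]1(C)/C=C/[C@@H](OC(=O)C=C(C)C)[C@](C)(O)/C=C/C(=O)/C(C[Si](c2ccccc2)(c2ccccc2)C(C)(C)C)=C\C1` — 38000 nM
Compound 3 `CC(C)=CCC[C@](C)(/C=C/[C@@H](OC(=O)C=C(C)C)[C@](C)(O)/C=C/C(=O)/C=C/N(C)C)CC=O` — 10300 nM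

Compound 1 gives the lowest number of the three; compound 3 and compound 2 both stand higher, each beyond the usual scatter, so compound 1 is the most potent here. Compound 4 `CC(C)=CCC[C@]1(C)/C=C/[C@@H](OC(=O)C=C(C)C)[C@](C)(O)/C=C/C(=O)/C(C(=O)N(C(C)C)C(C)C)=C\C1` differs from compound 1 in one place: diisopropylcarbamoyl in place of (dimethylamino)methyl on a double-bonded ring carbon. Among the measured compounds shown here, no measured pair shows exactly this step. For the measured compounds named here, the only other compound that carries a different group at that ring carbon, compound 2, gives 38000 nM in this assay, far weaker than compound 1. A weakening step of moderate size is therefore expected from compound 1 to compound 4, a 6.1-fold higher number from compound 1 to compound 4 (0.79 log units; beyond the scatter). Compound 4 is estimated at 5000 nM in this assay, within a range of 1500 nM to 20000 nM.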

Compound 4, half-maximal inhibitory concentration: 17200 nM
The estimate for compound 4 lay 3.4-fold (0.54 log units) below the measured number, and the stated range covers the measured number.
By their numbers in this assay, from the lowest: compound 1; then compounds 3 and 4 (each within the scatter of the next); then compound 2.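

In this assay, among the compounds shown here, the exchange of (dimethylamino)methyl for diisopropylcarbamoyl on the double-bonded ring carbon gives the first step that can be read at this position (a 21-fold higher number from compound 1 to compound 4 (1.32 log units; beyond the scatter)), and it shows that this single change costs a large part of the potency of compound 1. The entering group is larger and brings a carbonyl, and these two differences cannot be separated here. Nothing at hand accounts for the loss.

As far as these compounds go, it stays open whether a smaller amide such as dimethylcarbamoyl, an aminomethyl group or a carboxylic acid at this ring carbon would stand nearer to compound 1. Whether a longer chain ending in dimethylamino would do so also remains unanswered.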